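Trifluoromethyl for propyl in the anilino series

This account rests on a few compounds, and the source may have more. Where it says the series, first, only, none or still open, it means among the compounds named here.

The shared core carries an arylamino group, varied across three measured compounds. Compound 1 `Cc1ccc(NC2=CC(=O)c3nc4n(c3C2=O)[C@H]2OC[C@@H](O)[C@H]2OC4)cc1C` gives 2080 nM in a functional assay on MCF7 cells (Homo sapiens) for inhibition, read by sulforhodamine B assay; on this read-out lower numbers stand for stronger inhibition and higher numbers for weaker inhibition. Compound 3 `CCc1ccc(NC2=CC(=O)c3nc4n(c3C2=O)[C@H]2OC[C@@H](O)[C@H]2OC4)cc1` gives 960 nM in this assay, and the step of a 2.2-fold lower number from compound 1 to compound 3 (0.34 log units; beyond the scatter) is modest. Compound 2 `CCCc1ccc(NC2=CC(=O)c3c(nc4n3[C@H]3OC[C@@H](O)[C@H]3OC4)C2=O)cc1` reaches only the limit > 4000 nM in this assay. Compound 2 therefore stands apart from the two numbered compounds, carrying no number but the limit (the limit of > 4000 nM in this assay, at which 1 of the 3 values shown sits).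

Compound 4 `O=C1C(Nc2ccc(C(F)(F)F)cc2)=CC(=O)c2c1nc1n2[C@H]2OC[C@@H](O)[C@H]2OC1` differs from compound 2 in one place: trifluoromethyl in place of propyl on an aromatic carbon. Among the measured compounds shown here, no measured step covers this change; the single measured step, a 2.2-fold lower number from compound 1 to compound 3 (0.34 log units; beyond the scatter), concerns ethyl against dimethyl and says little about trifluoromethyl. Compound 2 offers only a limit. The size of the step to compound 4 cannot be set from the shown data, and a number somewhere within the range spanned by the numbered compounds is expected for compound 4, with a real chance that this assay again reports only a limit. Compound 4 is estimated at 2500 nM, between 800 nM and 8000 nM. The expected step is an at least 1.6-fold lower number from compound 2 to compound 4 (0.20 log units; that floor lies within the scatter).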

Compound 4, half-maximal inhibitory concentration: > 4000 nM
Compound 4: a limit, no number (the forecaster's own chance of this, stated with the estimate: 35%); at least 1.6-fold (0.20 log units) between middle value and limit.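

Compound 2 and compound 4 both end at a limit and not at a number, so the step between them cannot be read: the limit of > 4000 nM in this assay, at which 2 of the 4 values shown sit.

Left open is whether trifluoromethyl in place of propyl changes inhibition in this assay at all, and how far either compound lies past that limit.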